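Dithiocarbamate indole series: chloro for methyl on the core

The source may hold more compounds than are shown below. What is called first, only, known or untested is meant among the compounds shown, and "the series" means these compounds.

Measured so far in a functional assay on U-373MG ATCC cells (Homo sapiens) for inhibition, read by MTT assay, with a stated time of 72 h; on this read-out higher numbers stand for weaker inhibition of growth and lower numbers for stronger inhibition of growth:
Compound 1, `CCOC(=O)C1CCN(C(=S)Sc2c(-c3ccc(Br)cc3)[nH]c3ccc(C)cc23)CC1`, gives 68000 nM.
Compound 2, `CCN(CC)C(=S)Sc1c(-c2ccc(Br)cc2)[nH]c2ccc(Br)cc12`, gives 9000 nM.

Compound 1 stands at the highest of the two numbers in this assay. Among the compounds with values here, its nearest neighbour is compound 2, whose number is lower by a margin beyond the scatter; compound 2 differs from compound 1 in two places at once, in the amine part of the dithiocarbamate as well as on the core, so its two values show only that a halogenated core with a diethylamine gives the lower number, and no single change can be credited.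

Compound 3, `CCOC(=O)C1CCN(C(=S)Sc2c(-c3ccc(Br)cc3)[nH]c3ccc(Cl)cc23)CC1`, has not been measured in this assay. It differs from compound 1 in one place: chloro in place of methyl on an aromatic carbon. Within the data shown here, no step between measured compounds covers this change. Compound 2, with a halogen at the same place on the core and a lower number, is the only pointer, and it carries a second change. Compound 3 is expected to give a somewhat lower number than compound 1, a step of a 1.7-fold lower number from compound 1 to compound 3 (0.23 log units; within the scatter) that may not exceed the scatter. Compound 3 is estimated at 40000 nM, with a range from 15000 nM to 110000 nM.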

Compound 3, concentration for 50% growth inhibition: 33000 nM
Compound 3: the middle estimate sits 1.2-fold (0.08 log units) above what was measured; the measured number falls inside the stated range.
By their numbers in this assay, from the lowest: compound 2; then compound 3; then compound 1.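

In this assay, a 2.1-fold lower number from compound 1 to compound 3 (0.31 log units; beyond the scatter) gives the series its first comparison that differs in one place only, with the ethyl ester amine part of the dithiocarbamate and the 4-bromophenyl group held constant. The read-out therefore responds to this aromatic carbon of the shared core on its own, with chloro in place of methyl giving a modest shift that lies just beyond the usual scatter, whereas compound 2 could not separate a change on the core from a change in the amine part. No measurement is available that would explain this shift.

Still open is whether the same exchange gives a step of similar size when the amine part is the diethylamine of compound 2, since no matched pair with that amine part is shown. Also open, on these data alone, is how this place on the core responds to groups other than methyl, chloro and bromo, such as hydrogen, fluoro, methoxy or nitrile, and whether any of them moves the number further than chloro does.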